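The source may hold more compounds than are shown below. What is called first, only, known or untested is meant among the compounds shown, and "the series" means these compounds.

Measured so far:
compound 1 `O=C(Nc1cccc(-n2cc(-c3ccncc3)c(-c3ccc(Cl)c(O)c3)n2)c1)Nc1ccc(Cl)c(Cl)c1` — > 32500 nM
compound 2 `COc1cc(-c2nn(-c3cccc(NC(=O)c4cccc(C(F)(F)F)c4)c3)cc2-c2ccncc2)ccc1Cl` — > 50000 nM

Both values are limits of a functional assay on HCT-116 cells (Homo sapiens) for inhibition, read by sulforhodamine B assay, with a stated time of 48 h (on this read-out higher numbers stand for lower toxicity in this test and lower numbers for higher toxicity in this test), not numbers. In this assay compound 1 gives only a limit, > 32500 nM. In this assay compound 2 likewise gives only a limit, > 50000 nM, so compound 2 stands at the edge of what the read-out reports (the limit of > 50000 nM in this assay, at which 1 of the 2 values shown sits); the other value shown also sits at a limit (the limit of > 32500 nM in this assay, at which 1 of the 2 values shown sits).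

Compound 3 `COc1cc(-c2nn(-c3cccc(NC(=O)Nc4ccc(Cl)c(C(F)(F)F)c4)c3)cc2-c2ccncc2)ccc1Cl` follows from compound 2 by one change: (4-chloro-3-(trifluoromethyl)phenyl)amino in place of 3-(trifluoromethyl)phenyl on a carbonyl carbon. Among the measured compounds shown here, no step between measured compounds is available, and both measured values are limits, so there is no measured direction to lean on. Nothing in these values points to a change beyond the scatter in this assay. Compound 3 is expected to give again a limit or a value near it, estimated at 45000 nM with a range of 12000 nM to 150000 nM. The step of an at least 1.1-fold lower number from compound 2 to compound 3 (0.04 log units; that floor lies within the scatter) is expected to stay within the scatter.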

Compound 3, concentration lethal to 50% of the cells: 21500 nM
Compound 3: middle estimate off by 2.1-fold (0.32 log units), on the high side; the range from low to high includes it.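

In this assay, among the compounds shown here, compound 3 gives 21500 nM, the first value in this set that is a number and not a limit. With (4-chloro-3-(trifluoromethyl)phenyl)amino in place of 3-(trifluoromethyl)phenyl on a carbonyl carbon whose other neighbour is an amide-type nitrogen, the read-out shows an at least 2.3-fold lower number from compound 2 to compound 3 (0.36 log units; beyond the scatter), so this place can move the series towards higher toxicity in this test. That step gives only a floor for the size of the change, since compound 2 is read at a limit: the limit of > 50000 nM in this assay, at which 1 of the 3 values shown sits.

The amino link and the chlorine enter in one change, so the compounds shown do not separate their contributions to the step. Going by these compounds, how a carboxylic acid or a morpholine at this place would read in this assay also stays open.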